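The source may hold more compounds than are shown below. What is called first, only, known or untested is meant among the compounds shown, and "the series" means these compounds.

Compound 1 `NNCc1cc(O)n2nc(N)c([N+](=O)[O-])c2n1` gives 42.6 ug/mL in an ADME assay (Homo sapiens) for cytotoxicity; a lower number here means that less compound is tolerated, a higher number that more compound is tolerated.
Compound 2 `Nc1nn2c(O)cc(CNNC(N)S)nc2c1[N+](=O)[O-]` reaches only the limit of this assay, > 50 ug/mL.
Compound 3 `Nc1nn2c(O)cc(CNC(N)SCc3ccccc3)nc2c1[N+](=O)[O-]` likewise reaches only the limit of this assay, > 50 ug/mL.

Compound 3 therefore stands at the limit of > 50 ug/mL in this assay, at which 2 of the 3 values shown sit, and no number is known for it. Compound 4 `CCSC(N)NCc1cc(O)n2nc(N)c([N+](=O)[O-])c2n1` differs from it by methyl in place of phenyl on a saturated chain carbon bound to a sulfur. Going by the values given here, only one measured step exists, an at least 1.1-fold higher number from compound 1 to compound 2 (0.06 log units; that floor lies within the scatter), and it alters a different part of the molecule, so it bears on this change only weakly. Among the compounds with values here, nothing among the measured compounds points to a step beyond the scatter, so compound 4 is expected to sit at or near the same limit, an estimated a number no higher from compound 3 to compound 4 (the limit leaves the size open). The estimate for compound 4 is 50 ug/mL, within 30 ug/mL to 70 ug/mL.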

Compound 4, half-maximal cytotoxic concentration: > 50 ug/mL
Compound 4 ended at the assay's limit (the forecaster's own chance of this, stated with the estimate: 65%); the middle value sits exactly at the limit.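

In this assay the limit holds with methyl in place of phenyl on a saturated chain carbon bound to a sulfur, so in compound 4 reaching it does not depend on the benzyl group: the limit of > 50 ug/mL in this assay, at which 3 of the 4 values shown sit. The steps from compound 2 and from compound 3 to compound 4 cannot be read, as both ends of each are limits. Going by these compounds alone, the only readable step is an at least 1.1-fold higher number from compound 1 to compound 4 (0.06 log units; that floor lies within the scatter).

Any real difference between benzylsulfanyl and ethylsulfanyl stays hidden behind the limit. On these data alone, whether a longer chain or a carboxylic acid at this place would stay at the limit also remains open.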